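Notes on the step from compound 3 to compound 4

The compounds below may be only part of what the source reports. "The series", "measured", "known", "first", "only" and "open" are said of these compounds alone.

Compounds in a functional assay on MCF7 cells (Homo sapiens) for cytotoxicity, read by MTT assay, with a stated time of 24 h (a higher number here means a weaker inhibitor, a lower number a stronger inhibitor), so far:
- compound 1 (`Cc1ccc(/C=C2\CN(Cc3cn(Cc4ccc(F)cc4)nn3)C/C(=C\c3ccc(C)cc3)C2=O)cc1`) gives 29000 nM
- compound 2 (`Cc1ccc(/C=C2\CN(C(=S)SCc3cn(Cc4cccc(Cl)c4)nn3)C/C(=C\c3ccc(C)cc3)C2=O)cc1`) gives > 100000 nM as a limit of the assay, not a number
- compound 3 (`Cc1ccc(/C=C2\CN(Cc3cn(Cc4cccc(Cl)c4)nn3)C/C(=C\c3ccc(C)cc3)C2=O)cc1`) gives 10000 nM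
- compound 4 (`Cc1ccc(/C=C2\CN(Cc3cn(Cc4ccccc4Cl)nn3)C/C(=C\c3ccc(C)cc3)C2=O)cc1`) is not yet measured

Of the two actual numbers in the series, compound 3 holds the lower one (10000 nM), and compound 1 is its nearest neighbour. The next step keeps the chlorine on the ring but changes its place: 2-chlorophenyl in place of 3-chlorophenyl on a saturated chain carbon bound to an aromatic nitrogen. In words, this is 2-chlorophenyl in place of 3-chlorophenyl on a saturated chain carbon bound to an aromatic nitrogen, or 3-chlorobenzyl to 2-chlorobenzyl.

Among the measured compounds shown here, one measured step bears on this change, as it swaps the ring at the same place: a 2.9-fold lower number from compound 1 to compound 3 (0.46 log units; beyond the scatter). That step is modest and beyond the scatter, but it changes both the halogen and its place, so it gives no direction for moving the chlorine alone. A step in this assay no larger than that one is therefore expected, in either direction, and quite possibly none beyond the scatter. The estimated step is a 1.3-fold higher number from compound 3 to compound 4 (0.11 log units; within the scatter), a slight drift and not a firm call. For compound 4 the expected value is 13000 nM (estimated range 4500 nM to 40000 nM).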

Compound 4, half-maximal inhibitory concentration: 66700 nM
Estimate against measurement, compound 4: 5.1-fold (0.71 log units) below; the whole stated range lies below it.
By their numbers in this assay, from the lowest: compound 3; then compound 1; then compound 4. At a limit, above all of these: compound 2.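

In this assay the place of the chlorine matters on its own: the step reads a 6.7-fold higher number from compound 3 to compound 4 (0.82 log units; beyond the scatter), although 3-chlorophenyl and 2-chlorophenyl hold the same atoms and differ only in how these are joined. The comparison with the fluorinated analogue reads a 2.3-fold higher number from compound 1 to compound 4 (0.36 log units; beyond the scatter), so at this place, on a saturated chain carbon bound to an aromatic nitrogen, the numbers rise from 3-chlorophenyl through 4-fluorophenyl to 2-chlorophenyl, with each step printed as beyond the scatter, and having a chlorine on the ring does not by itself give the lower number. Nothing measured here accounts for the effect of moving the chlorine, and the shift remains an observation without an explanation.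

The compounds shown leave open how much of the difference between compound 1 and the two chlorinated compounds comes from the halogen and how much from its place. They also leave open where a plain phenyl stands against these three, and whether a bromine, a methoxy group or a nitrile on the ring follows the same order.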